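The source may hold more compounds than are shown below. What is called first, only, known or untested is meant among the compounds shown, and "the series" means these compounds.

Measured compounds:
- compound 1, `Cc1nnc(NC(=O)c2c(O)ccc3cc(-c4cccc(O)c4)ccc23)s1`: 73%
- compound 2, `N#Cc1cc(O)cc2ccc(-c3cccc(O)c3)cc12`: 99%
- compound 3, `N#Cc1cc(-c2cccc(O)c2)cc2ccc(O)cc12`: 53%

In an assay for inhibition of 17-beta-hydroxysteroid dehydrogenase type 1 (Homo sapiens), tested at 1 uM (on this read-out higher numbers stand for more inhibition at the one concentration tested (going by the name of the read-out) and lower numbers for less inhibition), compound 1 stands second highest of the three numbers. Its nearest neighbour is compound 3, whose inhibition lies lower, beyond the scatter; compound 2 lies furthest away, higher, also beyond the scatter. Compound 4, `O=S(=O)(c1ccccc1)c1c(O)ccc2cc(-c3cccc(O)c3)ccc12`, has not yet been measured. It differs from compound 1 by one change: phenylsulfonyl in place of (5-methyl-1,3,4-thiadiazol-2-yl)carbamoyl on an aromatic carbon. For the measured compounds named here, with no comparable step among the measured compounds, the expected step from compound 1 to compound 4 in this assay is estimated as small and downward, at a number 8 percentage points lower from compound 1 to compound 4 (within the scatter), close to the scatter. Compound 4 is thus estimated at 65%, within a range from 30% to 95%.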

Compound 4, a percentage reported as inhibition, at one concentration (the size of the read-out at that concentration, not a potency): 33%
Beside the measured number, compound 4's estimate is 32 percentage points above it, within the range that was stated.
By their numbers in this assay, from the lowest: compound 4; then compound 3; then compound 1; then compound 2.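

In this assay, the aromatic carbon ortho to a hydroxy group proves sensitive to its substituent: putting phenylsulfonyl in place of (5-methyl-1,3,4-thiadiazol-2-yl)carbamoyl gives a number 40 percentage points lower from compound 1 to compound 4 (beyond the scatter). The two groups match in heavy atoms but differ in ring and in hydrogen-bond donors, and this single pair cannot separate those differences. Nothing available explains the loss of inhibition. As far as these compounds go, it remains open how a simple phenylcarbamoyl group, which would keep the amide while replacing the thiadiazole, or a carboxylic acid or an amine would fare at this position.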